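The source may report more compounds than this note shows. Statements on the series, on what has been measured and on what is new or still open speak of the compounds shown alone.

In a functional assay on K562 cells (Homo sapiens) for antiproliferative activity, read by MTT assay, with a stated time of 5 days (a lower number here means a stronger inhibitor, a higher number a weaker inhibitor), compound 1 `COc1ccc(C(=Cc2ccc(OC)c(F)c2)C(=O)c2cc(OC)c(OC)c(OC)c2)cc1` gives 450000 nM and compound 2 `COc1cc(C(=O)C(=Cc2ccccc2)c2ccccc2)cc(OC)c1OC` gives 6300000 nM as the higher of the two numbers, a gap beyond the scatter that marks compound 2 as the weaker inhibitor. Compound 3 `COc1ccc(C(=Cc2ccccc2)C(=O)c2cc(OC)c(OC)c(OC)c2)cc1` differs from compound 2 by methoxy in place of hydrogen on an aromatic carbon in the form of methoxy in place of hydrogen on an aromatic carbon. Compound 1 carries this 4-methoxyphenyl too, alongside other differences, and its 450000 nM in this assay points to a moderate fall in the number, expected to lie beyond the scatter. The expected move is a 4.2-fold lower number from compound 2 to compound 3 (0.62 log units; beyond the scatter) in size. Compound 3 is estimated at 1500000 nM with an expected range of 450000 nM to 5000000 nM in this measurement.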

Compound 3, half-maximal inhibitory concentration: 4920000 nM
Estimate against measurement, compound 3: 3.3-fold (0.52 log units) below; the range from low to high includes it.
By their numbers in this assay, from the lowest: compound 1; then compounds 3 and 2 (each within the scatter of the next).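

In this assay, methoxy in place of hydrogen, para to a large group, leaves the number within the scatter, with a 1.3-fold lower number from compound 2 to compound 3 (0.11 log units; within the scatter) as the whole effect of phenyl to 4-methoxyphenyl. The large change lies at the other aryl group: phenyl in place of 3-fluoro-4-methoxyphenyl gives an 11-fold higher number from compound 1 to compound 3 (1.04 log units; beyond the scatter) on the double-bonded chain carbon. No measured evidence explains either step. The compounds shown leave open whether the fluoro or the methoxy group of that 3-fluoro-4-methoxyphenyl carries this step, and what an amine there would give.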